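The source may hold more compounds than are shown below. What is called first, only, known or untested is meant among the compounds shown, and "the series" means these compounds.

Series notes. Compound 1 `CCOC(=O)C12C(=O)OCC=C1COC2c1ccc(OC)c(OC)c1` and compound 2 `CCOC(=O)C12C(=O)OCC=C1COC2c1cc(OC)cc(OC)c1` share one core and differ only in where their methoxy groups sit on the aryl ring. In a functional assay on QGY cells (Homo sapiens) for cytotoxicity, read by MTT assay (on this read-out lower numbers stand for stronger inhibition and higher numbers for weaker inhibition), compound 1 gives > 1000000 nM, which is a limit of the assay and not a number. In this assay compound 2 likewise gives > 1000000 nM, again a limit rather than a number. Compound 2 therefore stands at the limit of > 1000000 nM in this assay, at which 2 of the 2 values shown sit. Compound 3 `CCOC(=O)C12C(=O)OCC=C1COC2c1cc(OC)c(OC)c(OC)c1` is the next member to be tested: methoxy in place of hydrogen on an aromatic carbon. Among the measured compounds shown here, no step between measured compounds is available, so no size of step can be taken from the data; since both measured values sit at the limit, no movement beyond the scatter is expected and compound 3 is expected to remain at the limit as well. The estimate for compound 3 in this assay is 1000000 nM, with a range of 300000 nM to 3000000 nM, which means an expected step of a number no higher from compound 2 to compound 3 (the limit leaves the size open).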

Compound 3, half-maximal inhibitory concentration: > 1000000 nM
Compound 3 ended at the assay's limit (the forecaster's own chance of this, stated with the estimate: 85%); the middle value sits exactly at the limit.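

No step from compound 1 or compound 2 to compound 3 can be read in this assay, as all three compounds sit at the same limit: the limit of > 1000000 nM in this assay, at which 3 of the 3 values shown sit.

The compounds shown leave open how compound 1, compound 2 and compound 3 compare in this assay, and what the added methoxy changes there.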